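A few compounds are considered here, and "the series" means these few. Any claim that something is new, unique, unknown or untested is made for them only; others in the source may bear on it.

Compound 1 `N#Cc1ccc(Nc2cc(NS(=O)(=O)c3ccc(F)cc3)ccn2)cc1` and compound 2 `N#Cc1ccc(Nc2cc(NS(=O)(=O)c3ccc(C(F)(F)F)cc3)ccn2)cc1` share one core and differ only by trifluoromethyl in place of fluoro on an aromatic carbon. In an ADME assay on MT4 cells (Homo sapiens) for cytotoxicity, read by MTT assay, with a stated time of 5 days (on this read-out higher numbers stand for lower toxicity in this test and lower numbers for higher toxicity in this test), compound 1 gives 6120 nM, and in this assay compound 2 gives 28000 nM, so the step of a 4.6-fold higher number from compound 1 to compound 2 (0.66 log units; beyond the scatter) points toward lower toxicity in this test. Compound 3 `N#Cc1ccc(Nc2nccc(NS(=O)(=O)c3ccc(F)cc3)n2)cc1` carries the fluoro group on a different core; the difference between the two cores is not broken down here. In this assay compound 3 gives 36600 nM, a value that lies within the usual scatter of the value of compound 2 and beyond the scatter of the value of compound 1. Compound 4 `N#Cc1ccc(Nc2nccc(NS(=O)(=O)c3ccc(C(F)(F)F)cc3)n2)cc1` is not yet measured. It differs from compound 3 by trifluoromethyl in place of fluoro on an aromatic carbon, the same change that separates compound 1 from compound 2. Because the step of a 4.6-fold higher number from compound 1 to compound 2 (0.66 log units; beyond the scatter) was modest and because compound 3 already gives 36600 nM, the step from compound 3 to compound 4 is expected to be a 2.7-fold higher number from compound 3 to compound 4 (0.44 log units; beyond the scatter). Compound 4 is therefore estimated at 100000 nM in this assay, with a likely range from 40000 nM to 250000 nM.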

Compound 4, half-maximal cytotoxic concentration: 54700 nM
Compound 4: middle estimate off by 1.8-fold (0.26 log units), on the high side, within the range that was stated.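

In this assay, putting trifluoromethyl in place of fluoro on the core of compound 3 gives a 1.5-fold higher number from compound 3 to compound 4 (0.17 log units; within the scatter), so this pair cannot be told apart in this test. The size of the step therefore did not carry over from one core to the other, and the gap between the two steps is larger than chance scatter would readily explain: the same change on two cores in this assay, a 4.6-fold higher number (0.66 log units; beyond the scatter) from compound 1 to compound 2 and a 1.5-fold higher number (0.17 log units; within the scatter) from compound 3 to compound 4, 3.1-fold (0.49 log units) apart, beyond the scatter of two such steps. Among these compounds, this shows that a step measured on one core was not a reliable guide to the step on the other here, but with only two pairs it gives no general rule for the series, and it does not show why the cores behave differently.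

The compounds shown leave open how an amine, a methoxy group or a carboxylic acid in the same place would read out on either core. They also leave open whether a third core would follow the larger step, the smaller one, or neither.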